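The compounds below may be only part of what the source reports. "The series", "measured", "known", "first", "only" and "open" are said of these compounds alone.

Compound 1 `CCCCCNC(=O)n1cc(-c2ccccc2)oc1=O` gives 39 nM in an assay on isolated protein for inhibition of acid ceramidase (Homo sapiens), read by LC-MS, with a stated time of 1 h; a higher number here means a weaker inhibitor, a lower number a stronger inhibitor. Compound 2 `CC(C)CNC(=O)n1cc(-c2ccccc2)oc1=O` gives 1700 nM in this assay. Compound 3 `COc1ccccc1-c1cn(C(=O)NCCCCc2ccccc2)c(=O)o1` gives 177 nM in this assay.

Compound 3 thus stands second highest of the three numbers, nearer to compound 1 than to compound 2. Compound 4 `O=C(NCCCCc1ccccc1)n1cc(-c2nccs2)oc1=O` differs from compound 3 by 1,3-thiazol-2-yl in place of 2-methoxyphenyl on an aromatic carbon. Within the data shown here, the only step measured between compounds differing in one place, a 44-fold higher number from compound 1 to compound 2 (1.64 log units; beyond the scatter), concerns the chain on the amide nitrogen and not the aromatic group on the core, so it does not bear on this change. Among the measured compounds shown here, no measured pair addresses a swap of that aromatic group, and the expectation rests on compound 3 alone. Compound 4 is expected to give 200 nM in this assay, within 50 nM to 800 nM. The expected step of a 1.1-fold higher number from compound 3 to compound 4 (0.05 log units; within the scatter) is therefore none beyond the scatter.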

Compound 4, half-maximal inhibitory concentration: 59 nM
Estimate against measurement, compound 4: 3.4-fold (0.53 log units) above; the measured number falls inside the stated range.
By their numbers in this assay, from the lowest: compounds 1 and 4 (each within the scatter of the next); then compound 3; then compound 2.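

Among these compounds, the aromatic group next to the ring oxygen proves able to move the number in this assay, a change the earlier compounds did not address: 1,3-thiazol-2-yl in place of 2-methoxyphenyl gives a 3.0-fold lower number from compound 3 to compound 4 (0.48 log units; beyond the scatter). With the chain of compound 3, this place therefore accepts a five-membered aromatic ring with 2 hetero atoms and no loss of strength. Nothing available accounts for this step.

Going by these compounds, what a pyridyl group would give at this place remains open, as does whether 1,3-thiazol-2-yl would bring a similar step with the chain of compound 1.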